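The source may hold more compounds than are shown below. What is called first, only, known or untested is meant among the compounds shown, and "the series" means these compounds.

Compound 1 `C=C1[C@H](O)C[C@@H]2[C@](C)(CO)[C@H](O)CC[C@@]2(C)[C@@H]1CCC1=CCOC1=O`: 22500 nM
Compound 2 `C=C1[C@@H](CCC2=CCOC2=O)[C@]2(C)CC[C@@H](O)[C@@](C)(CO)[C@H]2C[C@@H]1O`: 25200 nM
Compound 3 `C=C1CC[C@@H]2[C@](C)(CO)[C@H](O)CC[C@@]2(C)[C@@H]1CCC1=CCOC1=O`: 25500 nM

Of the compounds shown here, three sharing one core have been tested in a functional assay on HL-60 cells (Homo sapiens) for antiproliferative activity, read by trypan blue exclusion; on this read-out lower numbers stand for stronger inhibition of growth and higher numbers for weaker inhibition of growth. Compound 3 gives the highest of the three numbers, but its nearest neighbour is compound 2, and a 1.0-fold higher number from compound 2 to compound 3 (0.01 log units; within the scatter), while the step of a 1.1-fold higher number from compound 1 to compound 3 (0.05 log units; within the scatter) is equally small; the three values are therefore indistinguishable on this read-out. Compound 1 and compound 2 differ only in configuration, and a 1.1-fold higher number from compound 1 to compound 2 (0.05 log units; within the scatter), which is consistent with the fact that compounds 1 and 2 differ only in the configuration as drawn.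

Compound 4 `C=C1CC[C@@H]2[C@](C)(CO)[C@H](O)CC[C@@]2(C)[C@@H]1/C=C/C(=O)O` is not yet measured in this assay. Relative to compound 3, the change is a group of 5 heavy atoms (3 carbon, 2 oxygen; no ring) in place of a group of 8 heavy atoms (6 carbon, 2 oxygen; one five-membered non-aromatic ring with 1 hetero atom), on a saturated ring carbon, on a saturated ring carbon of a six-membered non-aromatic ring of carbon only, part of a fused system of two rings. None of the three measured steps touches this group: each removed a hydroxy or inverted a stereocentre, and each stayed within the scatter. Going by the values given here, there is thus no measured precedent for swapping the five-membered lactone ring for a 2-carboxyethenyl group, and the expectation for compound 4 rests on the unchanged core alone. Compound 4 is estimated at 50000 nM, within 15000 nM to 150000 nM, an expected step of a 2.0-fold higher number from compound 3 to compound 4 (0.29 log units; within the scatter), with wide uncertainty.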

Compound 4, concentration for 50% growth inhibition: 28800 nM
The estimate for compound 4 lay 1.7-fold (0.24 log units) above the measured number, within the range that was stated.
By their numbers in this assay, from the lowest: compounds 1, 2, 3 and 4 (each within the scatter of the next).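

In this assay, going by these compounds alone, the earlier compounds varied only a hydroxy group and one configuration, so they left the group on the saturated ring carbon of the six-membered ring untested. The new step now tests that group: 2-carboxyethenyl replaces the group with the five-membered non-aromatic ring, giving a 1.1-fold higher number from compound 3 to compound 4 (0.05 log units; within the scatter), so at this position neither the loss of that ring nor the arrival of the open chain with its carboxylic acid moves the number beyond the scatter. The only note on hand concerns the configuration of two other compounds and does not bear on this change, so the result comes with no explanation.

Going by these compounds, what an amine, an amide, a methyl ester or a longer saturated chain would do at this position remains open, as does whether the double bond of the 2-carboxyethenyl group or its drawn geometry matters. Since each of the four compounds lies within the scatter of the next in this assay, the compounds shown also leave open which change on this core, if any, would move the number beyond the scatter.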